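This account rests on a few compounds, and the source may have more. Where it says the series, first, only, none or still open, it means among the compounds named here.

Measured so far in a functional assay on A549 cells (Homo sapiens) for cytotoxicity, read by MTT assay, with a stated time of 4 h; a lower number here means a stronger inhibitor, a higher number a weaker inhibitor:
compound 1 `O=C1N=C(NN2Cc3ccccc3N=C2c2ccccc2)S/C1=C/c1ccc(Br)cc1` gives 21300 nM
compound 2 `O=C(CNc1ccc(Br)cc1)Nn1c(-c2ccccc2)nc2ccccc2c1=O` gives 25000 nM
compound 3 `COc1ccc(/C=C2/SC(NN3Cc4ccccc4N=C3c3ccccc3)=NC2=O)cc1` gives 5310 nM

Compound 2 gives the highest of the three numbers in this assay; compound 1 lies within the scatter of it, while compound 3 lies beyond the scatter below it. Compound 4 `O=C(CNc1ccc(Cl)cc1Cl)Nn1c(-c2ccccc2)nc2ccccc2c1=O` differs from compound 2 by 2,4-dichlorophenyl in place of 4-bromophenyl on an amine nitrogen. Within the data shown here, the only measured step is a 4.0-fold lower number from compound 1 to compound 3 (0.60 log units; beyond the scatter), which exchanges a halogen for methoxy on a different core and bears only loosely on a halogen-for-halogen exchange. Among the measured compounds shown here, no measured pair sets a dichlorophenyl against a bromophenyl. The expected step in this assay is therefore a 1.1-fold lower number from compound 2 to compound 4 (0.06 log units; within the scatter), within the scatter. Compound 4 is estimated at 22000 nM, with a range of 9000 nM to 55000 nM.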

Compound 4, half-maximal inhibitory concentration: 187000 nM
Estimate against measurement, compound 4: 8.5-fold (0.93 log units) below; measured number outside the range, above it.
By their numbers in this assay, from the lowest: compound 3; then compounds 1 and 2 (each within the scatter of the next); then compound 4.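

On the shared core of compound 2, the aryl group on the amine nitrogen is sensitive to its halogen pattern: in this assay the exchange of 4-bromophenyl for 2,4-dichlorophenyl gives a 7.5-fold higher number from compound 2 to compound 4 (0.87 log units; beyond the scatter). A change that keeps the aromatic ring and adds no hydrogen-bond donors or acceptors is therefore enough to move the number. No measurement at hand bears on what lies behind this step. With both halogen identity and pattern changing in one step, their separate contributions remain unresolved. An unsubstituted phenyl at this position would give a reference for both groups.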